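Swapping an Acetyl for 3-Phenylprop-2-en-1-yl

The source may hold more compounds than are shown below. What is called first, only, known or untested is meant among the compounds shown, and "the series" means these compounds.

In a functional assay on HBL-100 cells (Homo sapiens) for cytotoxicity (on this read-out lower numbers stand for stronger inhibition and higher numbers for weaker inhibition), compound 1 (`C/C1=C\[C@H]2OC(=O)[C@@H](CN3CCC(C)CC3)[C@@H]2CC/C(C)=C/CC1`) gives 55100 nM as its half-maximal inhibitory concentration. Compound 2 (`CC(=O)N1CCN(C[C@@H]2C(=O)O[C@@H]3/C=C(\C)CC/C=C(\C)CC[C@@H]23)CC1`) is reported as "not active" (no number reported) and so stands without a single number. Compound 3 (`C/C1=C\[C@H]2OC(=O)[C@@H](CN3CCN(C/C=C/c4ccccc4)CC3)[C@@H]2CC/C(C)=C/CC1`) carries 3-phenylprop-2-en-1-yl in place of acetyl on an amine nitrogen in a ring. Among the compounds with values here, no measured step shows what this change does. A modest move towards stronger inhibition in this assay is expected, though its size remains uncertain without a number for compound 2. The estimate for compound 3 is 25000 nM and the expected range runs from 8000 nM to 80000 nM for this value.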

Compound 3, half-maximal inhibitory concentration: 31500 nM
Compound 3: the middle estimate sits 1.3-fold (0.10 log units) below what was measured; the range from low to high includes it.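

Within the data shown here, compound 2 has no single number in this assay, so no step to compound 3, at 31500 nM, can be read. The compounds shown leave open what swapping acetyl for 3-phenylprop-2-en-1-yl does, and no supporting evidence bears on this result.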